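From trifluoromethyl to fluoro on the shared core

A few compounds are considered here, and "the series" means these few. Any claim that something is new, unique, unknown or untested is made for them only; others in the source may bear on it.

Compound 1 `COc1ccc(-n2c(-c3cc(OC)c(OC)c(OC)c3)cccc2=O)cc1O`: 1220 nM
Compound 2 `COc1cc(-c2cccc(=O)n2-c2ccc([N+](=O)[O-])cc2)cc(OC)c1OC`: 311 nM
Compound 3 `COc1cc(-c2cccc(=O)n2-c2ccc(C(F)(F)F)cc2)cc(OC)c1OC`: 1920 nM

In a functional assay on SK-OV-3 cells (Homo sapiens) for cytotoxicity, read by spectrophotometry, with a stated time of 72 h (on this read-out higher numbers stand for weaker inhibition and lower numbers for stronger inhibition), compound 3 gives 1920 nM, which lies within the scatter of compound 1 at 1220 nM. Compound 4 `COc1cc(-c2cccc(=O)n2-c2ccc(F)cc2)cc(OC)c1OC` carries fluoro in place of trifluoromethyl on an aromatic carbon, para to a large group: fluoro in place of trifluoromethyl on an aromatic carbon. Going by the values given here, two measured steps bear on this change, both modest: a 3.9-fold lower number from compound 1 to compound 2 (0.59 log units; beyond the scatter), and a 6.2-fold higher number from compound 2 to compound 3 (0.79 log units; beyond the scatter). Both run through compound 2, at 311 nM, and neither includes a fluoro compound, so no step beyond the scatter is expected in this assay. The estimated step is a 1.4-fold lower number from compound 3 to compound 4 (0.14 log units; within the scatter). Compound 4 is estimated at 1400 nM, with an expected range of 450 nM to 4000 nM.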

Compound 4, half-maximal inhibitory concentration: 9740 nM
Beside the measured number, compound 4's estimate is 7.0-fold (0.84 log units) below it; the whole stated range lies below it.
By their numbers in this assay, from the lowest: compound 2; then compounds 1 and 3 (each within the scatter of the next); then compound 4.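

In this assay, fluoro in place of trifluoromethyl is not a neutral change at this place, giving a 5.1-fold higher number from compound 3 to compound 4 (0.71 log units; beyond the scatter), while fluoro in place of nitro gives the large 31-fold higher number from compound 2 to compound 4 (1.50 log units; beyond the scatter). Going by these compounds alone, the comparison with the core of compound 1 points the same way, with an 8.0-fold higher number from compound 1 to compound 4 (0.90 log units; beyond the scatter), so compound 4 has the highest number of the four, a reach the earlier compounds did not show. Nothing measured here accounts for these steps. From the compounds shown here alone, whether chloro, nitrile or an amine at this place would stand nearer compound 2 or compound 4 remains open.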